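Benzyl to phenyl on the amide-type nitrogen: cytotoxicity notes

The compounds below may be only part of what the source reports. "The series", "measured", "known", "first", "only" and "open" are said of these compounds alone.

Compound 1 `CC(C)[C@H](NC(=S)NCc1ccccc1)c1nc2ccccc2[nH]1` carries a benzyl group on the amide-type nitrogen; in a functional assay on HeLa cells (Homo sapiens) for cytotoxicity, read by MTT assay (on this read-out higher numbers stand for weaker inhibition and lower numbers for stronger inhibition), compound 1 gives 49900 nM. Compound 2 `CC(C)[C@H](NC(=S)Nc1ccccc1)c1nc2ccccc2[nH]1` differs from it by phenyl in place of benzyl on an amide-type nitrogen. In this assay compound 2 gives 11100 nM, and the step reads a 4.5-fold lower number from compound 1 to compound 2 (0.65 log units; beyond the scatter). Compound 3 `C[C@@H](NC(=S)NCc1ccccc1)c1nc2ccccc2[nH]1` keeps the benzyl group on a different core; the difference between the two cores is not broken down here. In this assay compound 3 is reported as "not active" (no number reported), with no number behind it. Compound 4 `C[C@@H](NC(=S)Nc1ccccc1)c1nc2ccccc2[nH]1` stands to compound 3 as compound 2 stands to compound 1: phenyl in place of benzyl on an amide-type nitrogen. The place is described in the same words for both pairs, so this is the same change made twice among the four compounds.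

Among the measured compounds shown here, for compound 4 in this assay the only guide is the size of the step seen between the first pair, and the starting point is not a number. If compound 3 lies just beyond the top of the tested range, a shift like a 4.5-fold lower number from compound 1 to compound 2 (0.65 log units; beyond the scatter) would bring a phenyl analogue back into the measurable range, but only as a weak inhibitor. Compound 4 is therefore expected to give about 60000 nM in this assay, with a wide span from 20000 nM to 200000 nM, and a real chance that only a limit is reported again. This rests on one measured pair and on compound 3 showing "not active" (no number reported).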

Compound 4, half-maximal inhibitory concentration: 12400 nM
Compound 4: the middle estimate sits 4.8-fold (0.68 log units) above what was measured; the measured number lies below the stated range.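

In this assay, among the compounds shown here, compound 4 gives 12400 nM and compound 3 is reported as "not active" with no number behind it, so no step from compound 3 to compound 4 can be read. The compounds shown leave open whether phenyl in place of benzyl has the same size of step on the core of compound 3 as on the core of compound 1. No evidence bearing on this result is available.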